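The compounds below may be only part of what the source reports. "The series", "measured", "known", "first", "only" and "open" are said of these compounds alone.

Measured so far in a functional assay on QGY7701 cells (Homo sapiens) for cytotoxicity, read by MTT assay, with a stated time of 24 h; a lower number here means a stronger inhibitor, a higher number a weaker inhibitor:

compound 1, `C=CC1=C(C(=O)NCCCCC)C(c2ccc(Cl)c(Cl)c2)OC1`, gives > 100000 nM, which is a limit of this assay and not a number.
compound 2, `C=CC1=C(C(=O)Nc2ccccc2OC)C(c2ccc(F)cc2)OC1`, gives 52800 nM.

Compound 1 stands only at the limit of > 100000 nM in this assay, at which 1 of the 2 values shown sits, so no number places it against compound 2. Compound 3, `C=CC1=C(C(=O)Nc2ccccc2)C(c2ccc(Cl)c(Cl)c2)OC1`, is not yet measured in this assay. It differs from compound 1 in one place: phenyl in place of pentyl on an amide-type nitrogen, that is, pentylamino becomes anilino. Among the compounds with values here, no measured pair shows this change, so the size of its step is open. Within the data shown here, compound 2, the only compound with a number here, gives 52800 nM, and its value is taken as the rough region where a compound of this core that does register a number may sit. Compound 3 is therefore expected to be no weaker than compound 1 and possibly to register a number, with an expected step of an at least 1.4-fold lower number from compound 1 to compound 3 (0.15 log units; that floor lies within the scatter). The estimate for compound 3 in this assay is 70000 nM, within a range from 25000 nM to 200000 nM.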

Compound 3, half-maximal inhibitory concentration: > 100000 nM
Compound 3 gave a limit, no number; the forecaster's own chance of this, stated with the estimate: 45%; middle value at least 1.4-fold (0.15 log units) from the limit.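

In this assay compound 3 gives > 100000 nM, which is a limit and not a number. Within the data shown here, compound 1 also stands at a limit, so no step between compound 1 and compound 3 can be read: the limit of > 100000 nM in this assay, at which 2 of the 3 values shown sit. The compounds shown leave open whether phenyl in place of pentyl on an amide-type nitrogen changes the value at all.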